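One chloro added to compound 1

The compounds below may be only part of what the source reports. "The series", "measured", "known", "first", "only" and "open" are said of these compounds alone.

Measured so far in a functional assay on NCI-H460 cells (Homo sapiens) for inhibition; on this read-out higher numbers stand for weaker inhibition and lower numbers for stronger inhibition 
- compound 1 `O=C1NC(=O)c2c1c1c3ccccc3ncc1c1[nH]c3ccccc3c21` gives 660 nM 
- compound 2 `O=C1NC(=O)c2c1c1nc3ccccc3cc1c1[nH]c3ccccc3c21` gives 4040 nM 

Compound 1 holds the lower of the two numbers, so it is the stronger inhibitor, and the gap to compound 2 lies beyond the scatter. Among the measured compounds shown here, compound 3 `O=C1NC(=O)c2c1c1c3ccccc3ncc1c1[nH]c3cc(Cl)ccc3c21` keeps the core of compound 1 and carries chloro in place of hydrogen on an aromatic carbon as its only change. In this assay, for the measured compounds named here, no measured pair shows what this change does. The estimated step of a 1.1-fold lower number from compound 1 to compound 3 (0.04 log units; within the scatter) is expected to stay within the scatter. Compound 3 is expected near 600 nM with an estimated range from 150 nM to 2500 nM as a plausible span.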

Compound 3, half-maximal inhibitory concentration: 450 nM
Beside the measured number, compound 3's estimate is 1.3-fold (0.12 log units) above it; the range from low to high includes it.
By their numbers in this assay, from the lowest: compounds 3 and 1 (each within the scatter of the next); then compound 2.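

Putting chloro in place of hydrogen on this aromatic carbon gives a 1.5-fold lower number from compound 1 to compound 3 (0.17 log units; within the scatter) in this assay, so the two compounds cannot be told apart on this read-out. This carbon, meta to a fused ring and para to a fused ring, therefore carries one chlorine atom without a measurable loss of inhibition. No supporting information accounts for this outcome. Still open, as far as these compounds go, is whether an amine, a methoxy group or a carboxylic acid on this same carbon would be tolerated equally, and whether chloro on other aromatic carbons of the shared core would behave alike.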